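Dropping one cyano group: compound 1 to compound 3

A few compounds are considered here, and "the series" means these few. Any claim that something is new, unique, unknown or untested is made for them only; others in the source may bear on it.

Compound 1 `N#Cc1ccc(SCc2ccccc2)cc1C#N` gives 167 nM in an assay on microsomes for inhibition of Amine oxidase [flavin-containing] B (Homo sapiens), read by fluorescence and spectrophotometry, with a stated time of 20 min; on this read-out higher numbers stand for weaker inhibition and lower numbers for stronger inhibition. Going by the values given here, its only measured neighbour is compound 2 `CC(C)CCSc1ccc(C#N)c(C#N)c1`, which gives 242 nM in this assay; the step between them, a 1.4-fold higher number from compound 1 to compound 2 (0.16 log units; within the scatter), concerns isobutyl in place of phenyl on a saturated chain carbon bound to a sulfur and leaves the aromatic ring untouched. Compound 3 `N#Cc1ccc(SCc2ccccc2)cc1` differs from compound 1 by hydrogen in place of cyano on an aromatic carbon. Among the compounds with values here, no measured step bears on hydrogen in place of cyano on an aromatic carbon, so neither direction nor size of the shift in this assay can be anchored, and a wide range is appropriate. Compound 3 is estimated at 400 nM, between 100 nM and 2000 nM, an expected step of a 2.4-fold higher number from compound 1 to compound 3 (0.38 log units; beyond the scatter).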

Compound 3, half-maximal inhibitory concentration: 1580 nM
For compound 3 the middle estimate is 4.0-fold (0.60 log units) below the measured one, and the stated range covers the measured number.
By their numbers in this assay, from the lowest: compounds 1 and 2 (each within the scatter of the next); then compound 3.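

In this assay, going by these compounds alone, the cyano on the aromatic carbon ortho to a cyano group and meta to a group of 8 heavy atoms matters: hydrogen in its place gives a 9.5-fold higher number from compound 1 to compound 3 (0.98 log units; beyond the scatter) and is the first change to lie beyond the scatter. The earlier change, on the chain bound to sulfur, stayed within it. Nothing at hand explains this step.

As far as these compounds go, whether an amine, a methoxy group or a chlorine atom on this carbon would keep the number of compound 1 stays open. So does whether the step recurs with the isobutyl chain of compound 2.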